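Swapping chloro for iodo on an aromatic ring

The source may hold more compounds than are shown below. What is called first, only, known or untested is meant among the compounds shown, and "the series" means these compounds.

In a functional assay on HeLa cells (Homo sapiens) for antiproliferative activity, read by MTT assay, with a stated time of 48 h (a lower number here means a stronger inhibitor, a higher number a weaker inhibitor), compound 2 (`O=[N+]([O-])c1cccc(-c2nn(-c3ccccc3)cc2C(Nc2nc3ccc(Cl)cc3s2)c2c(O)ccc3ccccc23)c1`) gives 15500 nM, while compound 3 (`Oc1ccc2ccccc2c1C(Nc1nc2ccc(Cl)cc2s1)c1cn(-c2ccccc2)nc1-c1ccc(Cl)cc1`) gives 36800 nM. That is the highest number of the three measured compounds, so compound 3 is the weakest inhibitor among them. Compound 4 (`Oc1ccc2ccccc2c1C(Nc1nc2ccc(Cl)cc2s1)c1cn(-c2ccccc2)nc1-c1ccc(I)cc1`) changes compound 3 in one place, with iodo in place of chloro on an aromatic carbon, para to a large group, which turns 4-chlorophenyl into 4-iodophenyl: iodo in place of chloro on an aromatic carbon.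

Going by the values given here, the one measured step at this group is a 2.4-fold higher number from compound 2 to compound 3 (0.38 log units; beyond the scatter), with 4-chlorophenyl in place of 3-nitrophenyl. It shows that a change here can shift the number modestly. Compound 1 (`Oc1ccc2ccccc2c1C(Nc1nc2ccccc2s1)c1cn(-c2ccccc2)nc1-c1ccc(I)cc1`) already carries 4-iodophenyl and gives 6590 nM, but it lacks the chloro on the shared core that compound 4 keeps, so it is only a loose guide. A modest move towards a lower number is therefore expected in this assay.

This expectation amounts to a 1.8-fold lower number from compound 3 to compound 4 (0.26 log units; within the scatter). For compound 4 the estimated value is 20000 nM, with an expected range of 8000 nM to 45000 nM.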

Compound 4, half-maximal inhibitory concentration: 12100 nM
For compound 4 the middle estimate is 1.7-fold (0.22 log units) above the measured one, within the range that was stated.
By their numbers in this assay, from the lowest: compounds 1, 4 and 2 (each within the scatter of the next, the first and the last beyond it); then compound 3.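

In this assay, exchanging one halogen on the 4-chlorophenyl group is enough to move the result clearly, with a 3.0-fold lower number from compound 3 to compound 4 (0.48 log units; beyond the scatter), so this position responds to iodo in place of chloro alone. The other two single changes cannot be separated from the scatter: replacing 3-nitrophenyl with 4-iodophenyl gives a 1.3-fold lower number from compound 2 to compound 4 (0.11 log units; within the scatter), and chloro in place of hydrogen on the shared core, with 4-iodophenyl kept, gives a 1.8-fold higher number from compound 1 to compound 4 (0.26 log units; within the scatter). No measured evidence here accounts for the step from chloro to iodo.

From the compounds shown here alone, it remains open whether that step would hold on the core of compound 1, which lacks the chloro. Going by these compounds, how fluoro, an amine or a carboxylic acid would behave in place of the iodo also remains open.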